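This account rests on a few compounds, and the source may have more. Where it says the series, first, only, none or still open, it means among the compounds named here.

Measured so far:
compound 1, `CC(C)[C@@H](c1ccc(-c2ccc3cccc(F)c3c2)[nH]c1=O)[C@H]1OC(=O)NC1=O`, 1.93 h
compound 2, `CCc1cccc2ccc(-c3ccc(C(/C=C4\OC(=O)NC4=O)(CC)CC)c(=O)[nH]3)cc12`, 1.77 h

In an ADME assay on microsomes from liver (Rattus norvegicus) for metabolic stability (on this read-out lower numbers stand for a shorter-lived compound and higher numbers for a longer-lived compound), compound 1 gives 1.93 h, the higher of the two numbers shown, with compound 2 the nearest at 1.77 h; the gap between the two lies within the scatter, so neither can be called the longer-lived. For the measured compounds named here, no two measured compounds differ in only one place, so no measured step is available for the series.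

Compound 3, `CC(C)[C@H](C[C@H]1SC(=O)NC1=O)c1ccc(-c2ccc3cccc(F)c3c2)[nH]c1=O`, is not yet measured in this assay. It differs from compound 1 as follows: (2,4-dioxo-1,3-thiazolidin-5-yl)methyl in place of 2,4-dioxo-1,3-oxazolidin-5-yl on a saturated chain carbon bound to an aromatic carbon and a saturated chain carbon. Going by the values given here, with no measured step to lean on, the expectation for this assay is a change of no more than the scatter in either direction. The estimate for compound 3 in this assay is 1.6 h, within 0.7 h to 3.5 h, which means an expected step of a 1.2-fold lower number from compound 1 to compound 3 (0.08 log units; within the scatter).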

Compound 3, half-life: 0.143 h
For compound 3 the middle estimate is 11-fold (1.05 log units) above the measured one; measured number outside the range, below it.
By their numbers in this assay, from the lowest: compound 3; then compounds 2 and 1 (each within the scatter of the next).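

In this assay, the position on a saturated chain carbon bound to an aromatic carbon and a saturated chain carbon proves sensitive: replacing 2,4-dioxo-1,3-oxazolidin-5-yl with (2,4-dioxo-1,3-thiazolidin-5-yl)methyl gives a 13-fold lower number from compound 1 to compound 3 (1.13 log units; beyond the scatter). For the compounds shown here, this is the first measured step, and it shows that the group at this place can strongly shift the half-life on the shared core. The exchange brings in a ring sulfur and an extra carbon together, so the step belongs to the whole exchange, and nothing on hand gives a reason for it.

As far as these compounds go, whether the ring or the added carbon carries the loss stays open; 2,4-dioxo-1,3-thiazolidin-5-yl and (2,4-dioxo-1,3-oxazolidin-5-yl)methyl at this place would separate the two. How a carboxylic acid would behave here is also unknown.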